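The source may report more compounds than this note shows. Statements on the series, on what has been measured and on what is new or still open speak of the compounds shown alone.

Series around the shared core of compound 1 `CCCCOC(=O)C(O)Cn1cnc2c(N)ncnc21`, varied at the oxygen next to a carbonyl group. For the measured compounds named here, in a functional assay on PRK cells (Oryctolagus cuniculus) for cytotoxicity (a lower number here means that less compound is tolerated, a higher number that more compound is tolerated), compound 1 gives 200 ug/mL, the only outright number among the three values measured. Compound 2 `CC(C)(C)OC(=O)C(O)Cn1cnc2c(N)ncnc21` gives > 400 ug/mL, which is a limit of the assay. Compound 3 `Nc1ncnc2c1ncn2CC(O)C(=O)OCCO` likewise gives > 400 ug/mL, a limit of the assay. Both measured steps from compound 1 thus run upward to the limit of > 400 ug/mL in this assay, at which 2 of the 3 values shown sit: an at least 2.0-fold higher number from compound 1 to compound 2 (0.30 log units; that floor lies within the scatter) and an at least 2.0-fold higher number from compound 1 to compound 3 (0.30 log units; that floor lies within the scatter). Compound 4 `Nc1ncnc2c1ncn2CC(O)C(=O)OCc1ccco1` is not yet measured; it differs from compound 1 by furan-2-yl in place of propyl on a saturated chain carbon bound to an oxygen next to a carbonyl group. The two steps from compound 1 bear on this change only loosely, each reaching the limit, so a step upward or none beyond the scatter is expected, a 1.5-fold higher number from compound 1 to compound 4 (0.18 log units; within the scatter). Compound 4 is accordingly estimated at 300 ug/mL, with a range from 150 ug/mL to 400 ug/mL.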

Compound 4, minimum cytotoxic concentration: 40 ug/mL
The estimate for compound 4 lay 7.5-fold (0.88 log units) above the measured number, outside the stated range (below it).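

Furan-2-yl in place of propyl gives a 5.0-fold lower number from compound 1 to compound 4 (0.70 log units; beyond the scatter) in this assay, so this place on a saturated chain carbon bound to an oxygen next to a carbonyl group can also lower the number beyond the scatter. The other two comparisons give an at least 10-fold lower number from compound 3 to compound 4 (1.00 log units; beyond the scatter) and an at least 10-fold lower number from compound 2 to compound 4 (1.00 log units; beyond the scatter), and both sizes are floors only: the limit of > 400 ug/mL in this assay, at which 2 of the 4 values shown sit.

Open, as far as these compounds go, is whether the lower number follows the furan-2-yl ring as such or any ring here, which phenyl or thiophen-2-yl in its stead would tell. Also open, from the compounds shown here alone, is how a longer chain such as hexyl reads.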